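Trimming the Amine Substituent to a Bare Amino Group

A few compounds are considered here, and "the series" means these few. Any claim that something is new, unique, unknown or untested is made for them only; others in the source may bear on it.

This study looks at agonists of Toll-like receptor 8, with activity read in a functional assay on HEK293 cells for agonist activity at Toll-like receptor 8 (Homo sapiens), read by reporter gene assay; on this read-out lower numbers stand for an effect already at smaller amounts and higher numbers for an effect only at larger amounts of compound. Compound 1 `CCCCNc1oc2c(C)ncc(CO)c2c1Nc1ccccn1` carries a butylamino group on the shared core and gives 9380 nM. Compound 2 `CCCC(C)Nc1oc2c(C)ncc(CO)c2c1Nc1ccccn1` differs by a methyl on the chain carbon bound to the amine nitrogen and gives 9010 nM; the step of a 1.0-fold lower number from compound 1 to compound 2 (0.02 log units; within the scatter) shows that adding this methyl changes nothing beyond the scatter. Compound 3 `Cc1ncc(CO)c2c(Nc3ccccn3)c(NC(C)C)oc12`, which carries an isopropyl group on that nitrogen instead, gives "not active" (no number reported), with no number attached, so it stands apart from compounds 1 and 2 without a measured value of its own.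

Compound 4 `Cc1ncc(CO)c2c(Nc3ccccn3)c(N)oc12` is the next step: hydrogen in place of isopropyl on a nitrogen on an aromatic ring, so the isopropylamino group becomes a plain amino group. Among the measured compounds shown here, only one measured step is available, that from compound 1 to compound 2, and it concerns a change on a chain carbon rather than the removal of the whole substituent, so it bears on this step only loosely. With compound 3 already inactive and the substituent now removed entirely, compound 4 is expected to stay weak, with an estimated value of 30000 nM in this assay, in the range 8000 nM to 100000 nM, and a fair chance that no number is obtained at all.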

Compound 4, half-maximal effective concentration: "not active" (no number reported)
Compound 4: no number reported; there is nothing to compare the estimate with.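

Among the compounds shown here, compound 3 and compound 4 both come without a number, so no step between them can be read. Nothing available accounts for this result. The compounds shown leave open how the isopropylamino and amino compounds compare with each other, or with compound 1 and compound 2, on a numerical scale.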